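Cytotoxicity notes: one measured step pending in the series

A few compounds are considered here, and "the series" means these few. Any claim that something is new, unique, unknown or untested is made for them only; others in the source may bear on it.

Measured so far:
- compound 1, `CCc1ccc(-c2nc3c(c(C)nn3-c3ccccc3)c(-c3ccccc3C(=O)OC)c2C#N)cc1`: > 20000 nM
- compound 2, `Cc1ccccc1-c1nc2c(c(C)nn2-c2ccccc2)c(-c2ccccc2O)c1C#N`: 21000 nM

Going by the values given here, in an ADME assay on BJ cells (Homo sapiens) for cytotoxicity, with a stated time of 72 h (a lower number here means that less compound is needed, a higher number that more compound is needed for the effect), compound 2 gives 21000 nM, the only plain number in the set. For compound 1 the result is a limit of the assay, > 20000 nM. Compound 2 therefore sits right at the limit of > 20000 nM in this assay, at which 1 of the 2 values shown sits, so the two measured compounds cannot be ordered against each other.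

Compound 3, `CCc1cccc(-c2nc3c(c(C)nn3-c3ccccc3)c(-c3ccccc3O)c2C#N)c1`, differs from compound 2 in one place: 3-ethylphenyl in place of 2-methylphenyl on an aromatic carbon. Among the compounds with values here, no step between measured compounds exists here, so the effect of this kind of change on this assay cannot be read from the series itself. With both measured results at the top of the range, nothing beyond the scatter is expected for a 1.0-fold higher number from compound 2 to compound 3 (0.02 log units; within the scatter). Compound 3 is accordingly estimated at 22000 nM, within 9000 nM to 50000 nM, with a real chance that the assay reports only a limit.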

Compound 3, half-maximal effective concentration: > 20000 nM
Compound 3: only a limit was reported; the forecaster's own chance of this, stated with the estimate: 50%; the middle value lies beyond the limit too.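

The result for compound 3 is only a limit of the assay, so no step from compound 2 to compound 3 can be read in this assay: the limit of > 20000 nM in this assay, at which 2 of the 3 values shown sit.

The compounds shown leave open whether 3-ethylphenyl in place of 2-methylphenyl on an aromatic carbon shifts the read-out at all.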